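Swapping nitro for methoxy in a cytotoxic series

The compounds below may be only part of what the source reports. "The series", "measured", "known", "first", "only" and "open" are said of these compounds alone.

In a functional assay on SW480 cells (Homo sapiens) for cytotoxicity, read by MTT assay, with a stated time of 72 h (a higher number here means a weaker inhibitor of growth, a lower number a stronger inhibitor of growth), compound 1 (`N#C/C(=C/c1ccc2ccccc2c1)C(=O)c1ccc[nH]1`) gives < 10000 nM as a limit rather than a number. Compound 3 (`N#C/C(=C/c1ccc(Cl)c(Cl)c1)C(=O)c1ccc[nH]1`) likewise gives < 10000 nM as a limit. Compound 2 (`N#C/C(=C/c1ccc([N+](=O)[O-])cc1)C(=O)c1ccc[nH]1`) also gives < 10000 nM as a limit. Compound 2 therefore has no exact number to stand on (the limit of < 10000 nM in this assay, at which 3 of the 3 values shown sit), and no order among the three can be read.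

Compound 4 (`COc1ccc(/C=C(/C#N)C(=O)c2ccc[nH]2)cc1`) differs from compound 2 in one place (methoxy in place of nitro on an aromatic carbon): methoxy in place of nitro on an aromatic carbon, para to a large group. Within the data shown here, no two measured compounds here differ in only one place, so no measured step can guide the size of this one. With the limit of compound 2 at < 10000 nM as the only anchor, no change beyond the usual scatter is expected, in either direction. The expected change is a step that the limit leaves unreadable from compound 2 to compound 4 in this assay on this thin evidence. Compound 4 is expected at an estimated 5000 nM within a range of 1000 nM to 10000 nM and may again give only a limit.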

Compound 4, concentration for 50% growth inhibition: < 10000 nM
Compound 4 gave a limit, no number; the forecaster's own chance of this, stated with the estimate: 65%; the middle value does not contradict the limit.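

Among these compounds, compound 2 and compound 4 each stand only as a limit, not a number, so no step between them can be read: the limit of < 10000 nM in this assay, at which 4 of the 4 values shown sit.

Left open is how strongly each of the four compounds inhibits growth in this assay and whether methoxy in place of nitro changes that at all.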